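A few compounds are considered here, and "the series" means these few. Any claim that something is new, unique, unknown or untested is made for them only; others in the source may bear on it.

In a functional assay on the whole organism for inhibition, with Rattus norvegicus as the target, read by paw edema, in the formalin test, at a dose of 100 mg/kg by the intraperitoneal route (a higher number here means more inhibition at the dose given (going by the name of the read-out), a lower number less inhibition), compound 1 `O=c1cc(CNc2nc(-c3cc4cc(Br)cc(Br)c4oc3=O)cs2)c2cc(Cl)ccc2[nH]1` gives 2.85%. Its companion compound 2 `O=c1cc(CNc2nc(-c3cc4cc(Br)ccc4oc3=O)cs2)c2ccc(Cl)cc2[nH]1` gives 2.4% in this assay, and the two numbers lie within the scatter of each other, so compound 1 stands on a par with compound 2 rather than apart from it. Both results show almost no inhibition of the paw edema at the dose used. For the measured compounds named here, no measured pair in this set differs in a single place, so no measured step is available as a guide.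

Compound 3 `O=c1cc(CNc2nc(-c3cc4cc(Br)ccc4oc3=O)cs2)c2cc(Cl)ccc2[nH]1` differs from compound 1 in one place: hydrogen in place of bromo on an aromatic carbon. Going by the values given here, the bromo group that leaves is one of two on that ring in compound 1, and the only precedent for its absence is compound 2, whose value is indistinguishable from that of compound 1. The step of a number 0.2 percentage points higher from compound 1 to compound 3 (within the scatter) is therefore expected to stay within the scatter of this assay, with no direction to it. Compound 3 is expected to give about 3% in this assay, in a range from -6% to 12%.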

Compound 3, a percentage reported as inhibition, in the whole organism at one dose (the size of the read-out at that dose, not a potency): 3.03%
For compound 3 the middle estimate is 0 percentage points below the measured one; measured number inside the range.
By their numbers in this assay, from the lowest: compounds 2, 1 and 3 (each within the scatter of the next).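

In this assay, for the compounds shown here, hydrogen in place of bromo on an aromatic carbon, ortho to a fused ring and meta to a bromo group, gives a number 0.2 percentage points higher from compound 1 to compound 3 (within the scatter), the first step here that isolates a single place. The bromo group at this position is therefore not needed to hold the level seen in this pair, but that level is almost no inhibition of the paw edema in compound 1 (2.85%) and in compound 3 (3.03%), so the step describes this position only in compounds with very little effect at the dose given. Nothing available offers an explanation for this result.

As far as these compounds go, whether a different group at this position, such as an amine, a carboxylic acid or a methoxy group, would move inhibition clear of the scatter remains open. Also open, from the compounds shown here alone, is what hydrogen in place of the bromo group that remains on this ring in compound 3 would give.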